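Chalcone series: removing the amino group from compound 3

This account rests on a few compounds, and the source may have more. Where it says the series, first, only, none or still open, it means among the compounds named here.

Three chalcones have so far been measured in a functional assay on HepG2 cells (Homo sapiens) for cytotoxicity, read by sulforhodamine B assay, with a stated time of 48 h; a lower number here means a stronger inhibitor, a higher number a weaker inhibitor. Compound 1 `COc1ccc(/C=C/C(=O)c2cccc(-c3cccc(F)c3)c2)cc1` gives 1720 nM. Compound 2 `Nc1ccc(C(=O)/C=C/c2ccc(O)c(F)c2)cc1-c1ccc(F)cc1` gives 11700 nM. Compound 3 `COc1ccc(/C=C/C(=O)c2ccc(N)c(-c3ccc(F)cc3)c2)cc1OC` gives 3780 nM, which places it second highest of the three numbers: compound 1 lies at a lower number, beyond the scatter, and compound 2 at a higher number, also beyond the scatter.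

The next compound, compound 4 `COc1ccc(/C=C/C(=O)c2cccc(-c3ccc(F)cc3)c2)cc1OC`, differs from compound 3 in one place: hydrogen in place of amino on an aromatic carbon.

Among the measured compounds shown here, no step between two measured compounds isolates this change, so the expectation rests on the spread of the three numbers. For the measured compounds named here, compound 1 carries no amino group and gives 1720 nM, the lowest number so far, while both compounds bearing the amino group, compound 2 and compound 3, sit higher. A modest move toward a lower number is therefore expected, of a size around a 1.7-fold lower number from compound 3 to compound 4 (0.24 log units; within the scatter), though it may well remain inside the scatter. Compound 4 is estimated at 2200 nM, with a range from 900 nM to 5500 nM.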

Compound 4, half-maximal inhibitory concentration: 5370 nM
Compound 4: middle estimate off by 2.4-fold (0.39 log units), on the low side, within the range that was stated.
By their numbers in this assay, from the lowest: compound 1; then compounds 3 and 4 (each within the scatter of the next); then compound 2.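

Hydrogen in place of amino on this aromatic carbon, ortho to a 4-fluorophenyl group, gives a 1.4-fold higher number from compound 3 to compound 4 (0.15 log units; within the scatter) in this assay. Among the compounds shown here, this is the first pair to isolate the amino group, and with the dimethoxyphenyl end and the 4-fluorophenyl group held constant, the step shows no change that can be separated from the scatter, so compound 3 and compound 4 read alike. No measurement in hand offers an explanation for this result.

Still open, from the compounds shown here alone, is whether another group on this same aromatic carbon, such as an acetamide or a dimethylamino group, would give a step beyond the scatter. Also open, going by these compounds, is whether hydrogen in place of amino would read the same way with the other substituents of compound 2.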